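The source may hold more compounds than are shown below. What is called first, only, known or untested is meant among the compounds shown, and "the series" means these compounds.

The set comprises three compounds tested in a functional assay on A549 cells (Homo sapiens) for inhibition, read by MTT assay, with a stated time of 48 h (a higher number here means a weaker inhibitor, a lower number a stronger inhibitor), and a fourth not yet tested. Compound 1 `COc1ccc(-c2cc(NC(=O)Nc3ccncc3)cc(C(F)(F)F)c2)cn1` gives 276000 nM in this assay. Compound 2 `O=C(Nc1ccncc1)Nc1cc(-c2cncnc2)cc(C(F)(F)F)c1` gives 2420 nM. The change between them is pyrimidin-5-yl in place of 6-methoxypyridin-3-yl on an aromatic carbon and it produced a 110-fold lower number from compound 1 to compound 2 (2.06 log units; beyond the scatter). Compound 3 `COc1ccc(-c2ccc(OC(F)(F)F)c(NC(=O)Nc3nccs3)c2)cn1` gives 35000 nM; the difference between the core of compound 3 and the core of compound 1 is not broken down here. Compound 4 `O=C(Nc1nccs1)Nc1cc(-c2cncnc2)ccc1OC(F)(F)F` arises from compound 3 by the same kind of change, (pyrimidin-5-yl in place of 6-methoxypyridin-3-yl on an aromatic carbon). The surroundings of the place are not the same: in compound 1 it is meta to a large group and meta to a trifluoromethyl group, whereas in compound 3 it is meta to a ((1,3-thiazol-2-yl)carbamoyl)amino group and para to a trifluoromethoxy group. A lower number is expected for compound 4 because the earlier step was a 110-fold lower number from compound 1 to compound 2 (2.06 log units; beyond the scatter), but a smaller step, a 10-fold lower number from compound 3 to compound 4 (1.00 log units; beyond the scatter), is estimated, the surroundings of the two places being different. Compound 4 is therefore estimated at 3500 nM, with a range from 800 nM to 15000 nM.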

Compound 4, half-maximal inhibitory concentration: 17600 nM
Beside the measured number, compound 4's estimate is 5.0-fold (0.70 log units) below it; measured number outside the range, above it.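

In this assay, pyrimidin-5-yl in place of 6-methoxypyridin-3-yl gave a 2.0-fold lower number from compound 3 to compound 4 (0.30 log units; within the scatter), so the large step seen on the core of compound 1 was not repeated on the core of compound 3. The size of this change therefore did not carry over from one core to the other, and the two steps differ by more than the usual scatter: the same change on two cores in this assay, a 110-fold lower number (2.06 log units; beyond the scatter) from compound 1 to compound 2 and a 2.0-fold lower number (0.30 log units; within the scatter) from compound 3 to compound 4, 57-fold (1.76 log units) apart, beyond the scatter of two such steps This does not show which feature of the cores sets the size of the step, since the core of compound 1 and the core of compound 3 differ in more than one place, and two pairs give no general rule for the series.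

The compounds shown leave open whether the trifluoromethoxy group or the ((1,3-thiazol-2-yl)carbamoyl)amino group alone would shrink the step, and how a further core would respond to the same change. They also leave open what an amine or a carboxylic acid on that aromatic carbon would give.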